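Isopropyl in place of cyclopropyl: working notes

The source may hold more compounds than are shown below. What is called first, only, known or untested is meant among the compounds shown, and "the series" means these compounds.

Measured in a functional assay on SW1573 cells (Homo sapiens) for antiproliferative activity, read by sulforhodamine B assay, with a stated time of 48 h; on this read-out higher numbers stand for weaker inhibition of growth and lower numbers for stronger inhibition of growth:
Compound 1 `CCCC(C#CC(=O)OC)O/C=C/C(=O)OC` gives 320 nM
Compound 2 `CCC(C)C(C#CC(=O)OC)O/C=C/C(=O)OC` gives 910 nM
Compound 3 `COC(=O)C#CC(O/C=C/C(=O)OC)C1CC1` gives 1800 nM

Compound 3 shares the high end of the numbers with compound 2, as a 2.0-fold higher number from compound 2 to compound 3 (0.30 log units; within the scatter), while a 5.6-fold higher number from compound 1 to compound 3 (0.75 log units; beyond the scatter). Compound 4 `COC(=O)C#CC(O/C=C/C(=O)OC)C(C)C` has isopropyl in place of cyclopropyl on a saturated chain carbon bound to an oxygen on an unsaturated carbon and a triple-bonded carbon on a saturated chain carbon bound to an oxygen on an unsaturated carbon and a triple-bonded carbon. Within the data shown here, no measured step makes this exact change. The steps bearing on it are modest: a 2.8-fold higher number from compound 1 to compound 2 (0.45 log units; beyond the scatter), and the two above. The expected step is a 1.6-fold lower number from compound 3 to compound 4 (0.21 log units; within the scatter), which means no change beyond the scatter is expected. Compound 4 is estimated at 1100 nM. Its expected range runs from 450 nM to 2500 nM.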

Compound 4, concentration for 50% growth inhibition: 750 nM
For compound 4 the middle estimate is 1.5-fold (0.17 log units) above the measured one; the measured number falls inside the stated range.
By their numbers in this assay, from the lowest: compound 1; then compounds 4, 2 and 3 (each within the scatter of the next, the first and the last beyond it).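

In this assay, isopropyl and cyclopropyl at this carbon are not interchangeable despite the same count of 3 carbons (a 2.4-fold lower number from compound 3 to compound 4 (0.38 log units; beyond the scatter)). Isopropyl does not separate from the sec-butyl arrangement of compound 2 (a 1.2-fold lower number from compound 2 to compound 4 (0.08 log units; within the scatter)), whereas the unbranched propyl keeps its edge over isopropyl (a 2.3-fold higher number from compound 1 to compound 4 (0.37 log units; beyond the scatter)). No supporting data explain these steps.

Open, on these data alone, is whether a longer chain such as pentyl at this carbon would extend the trend from propyl, and how an amine or a carboxylic acid there would read.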